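Trifluoromethyl to Nitro: What to Expect for Compound 4

The source may hold more compounds than are shown below. What is called first, only, known or untested is meant among the compounds shown, and "the series" means these compounds.

Of the compounds shown here, three that share one core have been measured in a functional assay on MDA-MB-231 cells (Homo sapiens) for inhibition, read by MTT assay, with a stated time of 48 h; a higher number here means a weaker inhibitor, a lower number a stronger inhibitor. Compound 1 `COc1cc(/C=C/c2ccc(NC(=O)/C=C/c3ccc(C#N)cc3)cc2)cc(OC)c1` gives 7740 nM. Compound 2 `COc1cc(/C=C/c2ccc(OC(=O)/C=C/c3ccccc3)cc2)cc(OC)c1` gives 9810 nM, and compound 3 `COc1cc(/C=C/c2ccc(OC(=O)/C=C/c3ccc(C(F)(F)F)cc3)cc2)cc(OC)c1` gives 6910 nM. Compound 3 has the lowest of the three numbers, yet its gaps to compound 1 and to compound 2 both lie within the scatter, so the three cannot be ranked on these data. Among the measured compounds shown here, the one step that links two measured compounds differing in a single place is a 1.4-fold lower number from compound 2 to compound 3 (0.15 log units; within the scatter), in which trifluoromethyl replaces hydrogen on an aromatic carbon; it too falls within the scatter.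

Compound 4 `COc1cc(/C=C/c2ccc(OC(=O)/C=C/c3ccc([N+](=O)[O-])cc3)cc2)cc(OC)c1` is the next compound, and it differs from compound 3 by nitro in place of trifluoromethyl on an aromatic carbon. For the measured compounds named here, no measured pair shows this exact exchange. The closest guide is the step from compound 2 to compound 3, where a different change on an aromatic carbon moved the number only within the scatter. Exchanging one group for another at such a carbon is therefore expected to do little here. The step of a 1.1-fold lower number from compound 3 to compound 4 (0.03 log units; within the scatter) is the expected outcome. Compound 4 is estimated at 6500 nM, with a range from 3000 nM to 14000 nM.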

Compound 4, half-maximal inhibitory concentration: 18000 nM
The estimate for compound 4 lay 2.8-fold (0.44 log units) below the measured number; measured number outside the range, above it.
By their numbers in this assay, from the lowest: compounds 3, 1, 2 and 4 (each within the scatter of the next, the first and the last beyond it).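

The exchange of trifluoromethyl for nitro on this aromatic carbon, para to a large group, gives a 2.6-fold higher number from compound 3 to compound 4 (0.42 log units; beyond the scatter) in this assay and is the only step among these compounds that passes beyond the scatter. This shows that the choice of group at this position can shift the number, though only modestly. Each of the two groups has so far made little difference against hydrogen, yet they cannot be treated as interchangeable here. Set against hydrogen, nitro gives a 1.8-fold higher number from compound 2 to compound 4 (0.26 log units; within the scatter) and trifluoromethyl gives a 1.4-fold lower number from compound 2 to compound 3 (0.15 log units; within the scatter) and so neither separates from hydrogen on its own, while the two substituted compounds do separate from each other. No measurement shown here accounts for that gap.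

From the compounds shown here alone, whether an amine or a carboxylic acid on this same carbon would move the number further from that of compound 2, in either direction, remains open. Going by these compounds, it is also open whether the gap between nitro and trifluoromethyl would persist with the amide link seen in compound 1 in place of the ester link.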